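Allyl in place of methyl on the amine of compound 1

This account rests on a few compounds, and the source may have more. Where it says the series, first, only, none or still open, it means among the compounds named here.

Measured so far:
compound 1, `CN(CC[C@H](N)C(=O)O)C[C@H]1O[C@@H](n2cnc3c(N)ncnc32)[C@H](O)[C@@H]1O`, 30.3%
compound 2, `CC(C)N(CC[C@H](N)C(=O)O)C[C@H]1O[C@@H](n2cnc3c(N)ncnc32)[C@H](O)[C@@H]1O`, 44%
compound 3, `Nc1ncnc2c1ncn2[C@@H]1O[C@H](CN(CC[C@H](N)C(=O)O)CC2CCC2)[C@@H](O)[C@H]1O`, 32%

In an assay for inhibition of tRNA (cytosine(38)-C(5))-methyltransferase (Homo sapiens), with a stated time of 5 min, tested at 100 uM (a higher number here means more inhibition at the concentration tested (going by the name of the read-out), a lower number less inhibition), compound 1 gives the lowest of the three numbers; compound 3 sits within the scatter of it, compound 2 beyond it. The step of a number 13.7 percentage points higher from compound 1 to compound 2 (beyond the scatter) is modest; the step of a number 1.7 percentage points higher from compound 1 to compound 3 (within the scatter) is within the scatter, and a number 12 percentage points lower from compound 2 to compound 3 (beyond the scatter) is modest.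

Compound 4, `C=CCN(CC[C@H](N)C(=O)O)C[C@H]1O[C@@H](n2cnc3c(N)ncnc32)[C@H](O)[C@@H]1O`, differs from compound 1 by vinyl in place of hydrogen on a saturated chain carbon bound to an amine nitrogen. The nearest comparison is compound 3, where an addition at the same kind of carbon gave a number 1.7 percentage points higher from compound 1 to compound 3 (within the scatter). A step within the scatter is therefore expected, a number 3.7 percentage points higher from compound 1 to compound 4 (within the scatter). Compound 4 is estimated at 34%, between 24% and 46% in this assay.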

Compound 4, a percentage reported as inhibition, at one concentration (the size of the read-out at that concentration, not a potency): 53.9%
The estimate for compound 4 lay 19.9 percentage points below the measured number; the whole stated range lies below it.
By their numbers in this assay, from the lowest: compounds 1 and 3 (each within the scatter of the next); then compounds 2 and 4 (each within the scatter of the next).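

The allyl amine shows that a small addition at this carbon can matter, with a number 23.6 percentage points higher from compound 1 to compound 4 (beyond the scatter) for the change from methyl to allyl and a number 21.9 percentage points higher from compound 3 to compound 4 (beyond the scatter) against the cyclobutyl addition, whose own step from compound 1 stayed within the scatter. Allyl and isopropyl on the amine nitrogen are not separated, with a number 9.9 percentage points higher from compound 2 to compound 4 (within the scatter) as the step between them. Nothing available here accounts for these steps.

Open, going by these compounds, is whether propyl, the saturated chain of the same length, holds the value of compound 4. Also open, on these data alone, is how propargyl or a longer alkenyl chain such as butenyl would compare.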